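Removing the fluorine from the aryl group of compound 1

The source may report more compounds than this note shows. Statements on the series, on what has been measured and on what is new or still open speak of the compounds shown alone.

Measured so far in a functional assay on SGC-7901 cells (Homo sapiens) for antiproliferative activity, read by MTT assay, with a stated time of 72 h; on this read-out lower numbers stand for stronger inhibition and higher numbers for weaker inhibition:
- compound 1, `COc1cc(-n2cnc3ccc(-c4cccc(F)c4)cc32)cc(OC)c1OC`: 2490 nM
- compound 2, `COc1cc(-n2cnc3ccc(-c4cc(F)ccc4F)cc32)cc(OC)c1OC`: 6590 nM
- compound 3, `COc1cc(-n2cnc3ccc(-c4ccccc4Cl)cc32)cc(OC)c1OC`: the limit of > 10000 nM in this assay, at which 1 of the 3 values shown sits.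

Compound 1 stands lowest of the two numbers in this assay; compound 2 gives 6590 nM, a step of a 2.6-fold higher number from compound 1 to compound 2 (0.42 log units; beyond the scatter). Compound 3 gives only a limit of this assay, > 10000 nM. The step from compound 1 to compound 3 reads an at least 4.0-fold higher number from compound 1 to compound 3 (0.60 log units; beyond the scatter).

Compound 4, `COc1cc(-n2cnc3ccc(-c4ccccc4)cc32)cc(OC)c1OC`, differs from compound 1 by hydrogen in place of fluoro on an aromatic carbon. Both measured steps away from compound 1 raise the number, but neither removes a fluoro; the change is therefore expected to carry compound 4 no further than the scatter, with a 1.3-fold higher number from compound 1 to compound 4 (0.11 log units; within the scatter) as the expected step. Compound 4 is estimated at 3200 nM, between 1300 nM and 8000 nM.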

Compound 4, half-maximal inhibitory concentration: 290 nM
Compound 4: middle estimate off by 11-fold (1.04 log units), on the high side, outside the stated range (below it).
By their numbers in this assay, from the lowest: compound 4; then compound 1; then compound 2. At a limit, above all of these: compound 3.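

Hydrogen in place of fluoro gives an 8.6-fold lower number from compound 1 to compound 4 (0.93 log units; beyond the scatter), so the unsubstituted phenyl, which the earlier halogenated compounds could not show, is the best aryl group in the set, and every halogenated ring shown gives a higher number. The same comparison reads a 23-fold lower number from compound 2 to compound 4 (1.36 log units; beyond the scatter) for 2,5-difluorophenyl and an at least 34-fold lower number from compound 3 to compound 4 (1.53 log units; beyond the scatter) for 2-chlorophenyl, the latter only a floor. Compound 3 stands at a limit: the limit of > 10000 nM in this assay, at which 1 of the 4 values shown sits.

On these data alone, it remains open whether only halogens raise the number here or any added group does. A methyl, a methoxy or an amine on the same ring would separate the two.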